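This account rests on a few compounds, and the source may have more. Where it says the series, first, only, none or still open, it means among the compounds named here.

Of the compounds shown here, two sharing one core have been measured in an ADME assay on microsomes from liver (Rattus norvegicus) for metabolic stability, read by LC-MS, using NADPH, at 37 degrees C; a lower number here means that the compound disappears faster, a higher number that the compound lasts longer. Compound 1 `Cc1oc(-c2ccccc2Cl)nc1CN1CCC(C(=O)NCCCN2C[C@H](C)C[C@H](C)C2)CC1` gives 0.25 h, and compound 2 `Cc1cccc(F)c1-c1nc(CN2CCC(C(=O)NCCCN3C[C@H](C)C[C@H](C)C3)CC2)c(C)o1` gives 0.0733 h, the lower of the two numbers and the shorter-lived compound of the pair. Compound 3 `Cc1cccc(C)c1-c1nc(CN2CCC(C(=O)NCCCN3C[C@H](C)C[C@H](C)C3)CC2)c(C)o1` differs from compound 2 in a single place: methyl in place of fluoro on an aromatic carbon. In words, this is methyl in place of fluoro on an aromatic carbon, turning 2-fluoro-6-methylphenyl into 2,6-dimethylphenyl.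

For the measured compounds named here, only one measured step bears on this change, and only indirectly. Replacing 2-chlorophenyl with 2-fluoro-6-methylphenyl gave a 3.4-fold lower number from compound 1 to compound 2 (0.53 log units; beyond the scatter), a modest step beyond the scatter. Going by the values given here, that step removed a chloro group, whereas the new change removes a fluoro group, and no measured pair isolates the fluoro-to-methyl swap. The earlier step therefore offers a rough bound on size rather than a direction, so no clear move is expected. The expected outcome is a 1.0-fold lower number from compound 2 to compound 3 (0.02 log units; within the scatter), which would stay within the scatter. Compound 3 is estimated at 0.07 h, with an expected range from 0.03 h to 0.16 h.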

Compound 3, half-life: 0.0517 h
The estimate for compound 3 lay 1.4-fold (0.13 log units) above the measured number, within the range that was stated.
By their numbers in this assay, from the lowest: compounds 3 and 2 (each within the scatter of the next); then compound 1.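

At the place that carries fluoro in the 2-fluoro-6-methylphenyl group, this assay does not separate fluoro from methyl: the swap gives a 1.4-fold lower number from compound 2 to compound 3 (0.15 log units; within the scatter), which stays within the scatter and supplies the direct reading of this exchange that the first pair could not give. Measured against the 2-chlorophenyl group, 2,6-dimethylphenyl gives a 4.8-fold lower number from compound 1 to compound 3 (0.68 log units; beyond the scatter), a step beyond the scatter like a 3.4-fold lower number from compound 1 to compound 2 (0.53 log units; beyond the scatter), so the shorter half-life seen with compound 2 is still present in compound 3, which carries no fluoro group. No evidence at hand accounts for the gap between compound 1 and the other two compounds or for the closeness of compound 2 and compound 3.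

The compounds shown leave open whether this half-life would hold with a methoxy or a trifluoromethyl group at the same place on the six-membered aromatic ring. They also leave open whether a longer chain on the amide of the shared core would change the half-life of compound 3 to a greater extent than these changes on the aromatic ring.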